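The source may hold more compounds than are shown below. What is called first, only, known or untested is meant among the compounds shown, and "the series" means these compounds.

Of the compounds shown here, three share one core and have been measured in a physicochemical assay for lipophilicity, in phosphate buffer, measured as octanol-water partition, with a stated time of 24 h; on this read-out lower numbers stand for lower lipophilicity and higher numbers for higher lipophilicity. Compound 1 `Cc1ccc(Oc2ccc(/C=N/NC(=S)Nc3ccccc3)cc2)cc1` gives 5.39 in this assay and stands lowest of the three. Compound 2 `Cc1ccc(Oc2ccc(/C=N/NC(=S)Nc3ccc(Cl)cc3)cc2)cc1` gives 5.97, and compound 3 `Cc1ccc(Oc2ccc(/C=N/NC(=S)Nc3ccc(F)cc3)cc2)cc1` gives 5.48. The step of a number 0.58 log units higher from compound 1 to compound 2 (beyond the scatter) lies beyond the scatter, whereas the step of a number 0.09 log units higher from compound 1 to compound 3 (within the scatter) lies within it; the step of a number 0.49 log units lower from compound 2 to compound 3 (beyond the scatter) is again beyond the scatter.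

Compound 4 `Fc1ccc(Oc2ccc(/C=N/NC(=S)Nc3ccccc3)cc2)cc1` has not yet been measured. It differs from compound 1 in one place: fluoro in place of methyl on an aromatic carbon. Going by the values given here, none of the measured steps changes a methyl, so none bears on this exchange directly. The closest comparison is the entry of fluoro in the step from compound 1 to compound 3, which stayed within the scatter. Fluoro here replaces a methyl rather than hydrogen, and the outcome is expected to be a small downward move, a number 0.29 log units lower from compound 1 to compound 4 (within the scatter), though this is uncertain. Compound 4 is therefore estimated at 5.1 in this assay, within a range of 4.7 to 5.5.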

Compound 4, partition coefficient: 5.09
Compound 4: the middle estimate sits 0.01 log units above what was measured; the measured number falls inside the stated range.
By their numbers in this assay, from the lowest: compounds 4, 1 and 3 (each within the scatter of the next, the first and the last beyond it); then compound 2.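

Going by these compounds alone, the replacement of the methyl in the 4-methylphenoxy group by fluoro gives the first measured step at this position, since the earlier steps all involved hydrogen, chloro or fluoro at another place in the shared core. In this assay, a number 0.30 log units lower from compound 1 to compound 4 (within the scatter) shows that this exchange, with one heavy atom leaving and one entering, stays within the usual scatter, so compound 4 cannot be told apart from compound 1 on this read-out. Nothing available explains this outcome.

The compounds shown leave open whether chloro, a methoxy group, an amine or a carboxylic acid at this position would give a step beyond the scatter. They also leave open how the same exchange would read with chloro in place of hydrogen at the other end of the molecule.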